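The compounds below may be only part of what the source reports. "The series", "measured", "known", "first", "only" and "open" are said of these compounds alone.

Compound 1, `CCCC(=O)N1CCC(c2cc(OC)ccc2N)=N1`: 13.1% in an assay on isolated protein for inhibition of Nitric oxide synthase, inducible (Homo sapiens), with a stated time of 30 min, tested at 1 mM; a lower number here means less inhibition, a higher number more inhibition at the concentration tested (going by the name of the read-out)
Compound 2, `COc1ccc(N)c(C2=NN(C(=O)C3CCCC3)CC2)c1`: 1.85% in this assay

For the measured compounds named here, compound 2 holds the lower of the two numbers measured so far; its only neighbour is compound 1, whose inhibition lies higher by a margin beyond the scatter. Going by the values given here, the single measured step, a number 11.3 percentage points lower from compound 1 to compound 2 (beyond the scatter), went with cyclopentyl in place of propyl on a carbonyl carbon, a modest fall when a chain gave way to a ring. Compound 3, `COc1ccc(N)c(C2=NN(C(=O)c3ccccc3)CC2)c1`, has not been measured. It differs from compound 2 in one place: phenyl in place of cyclopentyl on a carbonyl carbon. The measured step bears on this only loosely, since it traded a chain for a ring, whereas here one ring replaces another ring of similar size at the same carbonyl carbon. Among the compounds with values here, no measured pair shows what such a ring-for-ring exchange does. Within the data shown here, with the only known step modest and not of the same kind, the change from compound 2 to compound 3 is expected to stay within the scatter, a number 2.2 percentage points higher from compound 2 to compound 3 (within the scatter). Compound 3 is therefore estimated at 4% in this assay, with a range from -6% to 15%.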

Compound 3, a percentage reported as inhibition, at one concentration (the size of the read-out at that concentration, not a potency): 12.2%
Compound 3: the middle estimate sits 8.2 percentage points below what was measured; low and high end bracket the measured number.
By their numbers in this assay, from the lowest: compound 2; then compounds 3 and 1 (each within the scatter of the next).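

The earlier pair left open whether any ring on this carbonyl carbon would lower the number, and compound 3 shows that it does not: in this assay, phenyl in place of cyclopentyl gives a number 10.4 percentage points higher from compound 2 to compound 3 (beyond the scatter) and so reverses the earlier fall. For the compounds shown here, with phenyl in place of propyl, the comparison gives a number 0.9 percentage points lower from compound 1 to compound 3 (within the scatter) and so separates neither group from the other, leaving cyclopentyl as the only one of the three groups that stands apart. No available evidence explains why a five-membered non-aromatic ring of carbon only behaves differently here from a six-membered aromatic ring of carbon only.

Phenyl differs from cyclopentyl in both ring size and aromatic character, so a cyclohexyl group would be needed to tell these two changes apart. From the compounds shown here alone, it also remains open how a longer chain, a pyridyl ring or a phenyl ring carrying an amine would behave at this carbonyl carbon, and all these readings, taken at one concentration, show the size of the effect there rather than a potency.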